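Replacing one aromatic group on compound 1

This account rests on a few compounds, and the source may have more. Where it says the series, first, only, none or still open, it means among the compounds named here.

In an in vitro ADME assay on microsomes from liver (Rattus norvegicus) for metabolic stability (on this read-out higher numbers stand for fast clearance and lower numbers for slow clearance), compound 1 (`CC(C)NC(=O)[C@H]1CC[C@@H](n2/c(=N/C(=O)c3ccc(C#N)c(F)c3)[nH]c3ccc(CN4CCC(C(C)(C)O)CC4)cc32)CC1`) gives 29 mL.min-1.g-1 as the lowest of three numbers. Compound 2 (`COC(=O)[C@H]1CC[C@@H](n2/c(=N/C(=O)c3ccccc3)[nH]c3ccc(CN4CCCCC4)cc32)CC1`) reaches 459 mL.min-1.g-1 and compound 3 (`C=CCNS(=O)(=O)c1cccc(C(=O)/N=c2\[nH]c3cc(CN4CCCCC4)ccc3n2[C@H]2CC[C@@H](CO)CC2)c1`) reaches 314 mL.min-1.g-1 on the same scale, and both gaps to compound 1 lie beyond the scatter. Compound 4 (`CC(C)NC(=O)[C@H]1CC[C@@H](n2/c(=N/C(=O)c3cccnc3)[nH]c3ccc(CN4CCC(C(C)(C)O)CC4)cc32)CC1`) carries pyridin-3-yl in place of 4-cyano-3-fluorophenyl on a carbonyl carbon. Among the measured compounds shown here, no two measured compounds differ in one place only, so no measured step guides this swap. The expectation therefore starts from compound 1 at 29 mL.min-1.g-1 and assumes no step beyond the scatter in this assay for now. The expected step is a 1.0-fold higher number from compound 1 to compound 4 (0.01 log units; within the scatter) and remains uncertain. Compound 4 is estimated at 30 mL.min-1.g-1 (expected range 12 mL.min-1.g-1 to 75 mL.min-1.g-1).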

Compound 4, intrinsic clearance in microsomes: < 14 mL.min-1.g-1
Compound 4: a limit, no number; the forecaster's own chance of this, stated with the estimate: 2%; at least 2.1-fold (0.33 log units) between middle value and limit.
By their numbers in this assay, from the lowest: compound 1; then compounds 3 and 2 (each within the scatter of the next). At a limit, below all of these: compound 4.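

In this assay, pyridin-3-yl in place of 4-cyano-3-fluorophenyl on a carbonyl carbon gives an at least 2.0-fold lower number from compound 1 to compound 4 (0.31 log units; beyond the scatter). Among the compounds shown here, this is the first step here that changes one place only, and it shows that the aromatic group at this position can alone shift the read-out beyond the scatter. Compound 4 gives < 14 mL.min-1.g-1, which is a limit and not a number, so its full step cannot be read: the limit of < 14 mL.min-1.g-1 in this assay, at which 1 of the 4 values shown sits.

From the compounds shown here alone, the nitrile, the fluorine and the ring nitrogen all change together, so their separate shares remain open. Going by these compounds, how pyridin-4-yl or pyrimidin-5-yl would read at this position also remains open.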